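A few compounds are considered here, and "the series" means these few. Any claim that something is new, unique, unknown or untested is made for them only; others in the source may bear on it.

Measured compounds in an in vitro functional assay on cells for agonist activity at Bombesin receptor subtype-3 (Mus musculus), read by luminescence and calcium flux; a higher number here means that more compound is needed for the effect, a lower number that less compound is needed:
Compound 1 `O=C(O)c1ccccc1-c1ccc(CCc2ncc(CC3CCCC3)[nH]2)cc1` gives 7.9 nM.
Compound 2 `O=C(O)c1ccccc1-c1ccc(CCc2ncc(Cc3ccc(F)cc3)[nH]2)cc1` gives 50 nM.

Compound 2 stands at the higher of the two numbers in this assay; its nearest neighbour is compound 1, separated by a 6.3-fold higher number from compound 1 to compound 2 (0.80 log units; beyond the scatter). That single step is the only one that bears on the next compound. Compound 3 `O=C(O)c1ccccc1-c1ccc(CCc2ncc(CC3CC3)[nH]2)cc1` is made from compound 2 by cyclopropyl in place of 4-fluorophenyl on a saturated chain carbon bound to an aromatic carbon. The change runs the earlier step partly in reverse: the aromatic ring leaves the saturated chain carbon and a saturated carbocycle returns, though a three-membered one rather than the five-membered ring of compound 1. The expectation therefore rests on compound 1, whose value of 7.9 nM shows that a saturated ring at this place can give a low number. Among the compounds with values here, with only one step to lean on, the expected direction is downward and the expected size is modest, a 2.5-fold lower number from compound 2 to compound 3 (0.40 log units; beyond the scatter), smaller than a full return to compound 1 since the ring that enters is the smaller one. For compound 3 the estimate in this assay is 20 nM, within 6 nM to 60 nM.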

Compound 3, half-maximal effective concentration: 72 nM
For compound 3 the middle estimate is 3.6-fold (0.56 log units) below the measured one; measured number outside the range, above it.
By their numbers in this assay, from the lowest: compound 1; then compounds 2 and 3 (each within the scatter of the next).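

In this assay, cyclopropyl and 4-fluorophenyl on a saturated chain carbon bound to an aromatic carbon cannot be told apart (a 1.4-fold higher number from compound 2 to compound 3 (0.16 log units; within the scatter)), so exchanging the aromatic ring for this saturated carbocycle gives no readable change at this place. The low number of compound 1 therefore does not extend to every saturated carbocycle here: the listed comparison with the smaller ring shows a 9.1-fold higher number from compound 1 to compound 3 (0.96 log units; beyond the scatter), and among these three compounds cyclopentyl alone stands apart from the other two groups, with both of its steps beyond the scatter. The data at hand offer no measurement that accounts for this separation between the two saturated rings.

Going by these compounds, whether the number follows ring size in a graded way or cyclopentyl is a lone favourable case remains open, and cyclobutyl and cyclohexyl on the same chain carbon would bear directly on that question. Also open, on these data alone, is whether a ring is needed at all, which an open chain such as isobutyl could address, and whether the fluorine of compound 2 has any bearing on its number, which unsubstituted benzyl in place of 4-fluorobenzyl could address.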